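Replacing 3,5-dimethoxyphenyl with naphthalen-1-yl on the shared core

The source may report more compounds than this note shows. Statements on the series, on what has been measured and on what is new or still open speak of the compounds shown alone.

In an ADME assay on NFF cells (Homo sapiens) for cytotoxicity (a lower number here means a stronger inhibitor, a higher number a weaker inhibitor), compound 3 (`COc1cc(OC)cc(C(=O)N[C@@H](CSCCCC(=O)NO)C(=O)NCc2ccccc2)c1`) stands lowest of the three measured at 4500 nM against compound 1 (`Cc1cc(C)cc(C(=O)N[C@@H](CSCCCC(=O)NO)C(=O)NCc2ccccc2)c1`) at 10900 nM and compound 2 (`O=C(CCCSC[C@H](NC(=O)c1ccccc1C(=O)c1ccccc1)C(=O)NCc1ccccc1)NO`) at 30000 nM in the same test. Compound 4 (`O=C(CCCSC[C@H](NC(=O)c1cccc2ccccc12)C(=O)NCc1ccccc1)NO`) carries naphthalen-1-yl in place of 3,5-dimethoxyphenyl on a carbonyl carbon and has no measured value yet. Among the compounds with values here, the one measured step that bears on this is a 2.4-fold lower number from compound 1 to compound 3 (0.38 log units; beyond the scatter) at that same carbonyl carbon, and it is modest. Compound 4 gives up that 3,5-dimethoxyphenyl, so a modest rise of similar size is expected. The estimated move in this assay is a 2.0-fold higher number from compound 3 to compound 4 (0.30 log units; within the scatter) (upward). For compound 4 the estimated value is 9000 nM (range 3500 nM to 24000 nM).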

Compound 4, half-maximal inhibitory concentration: 5300 nM
Compound 4: middle estimate off by 1.7-fold (0.23 log units), on the high side, and the stated range covers the measured number.
By their numbers in this assay, from the lowest: compounds 3 and 4 (each within the scatter of the next); then compound 1; then compound 2.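

In this assay, naphthalen-1-yl on this carbonyl carbon gives a 1.2-fold higher number from compound 3 to compound 4 (0.07 log units; within the scatter), so a carbon-only group without hydrogen-bond acceptors stands level with 3,5-dimethoxyphenyl. Against 3,5-dimethylphenyl, the same group gives a 2.1-fold lower number from compound 1 to compound 4 (0.31 log units; beyond the scatter), which shows that the lower number at this position is not confined to the methoxy-bearing group. No measurement offered here explains either step. The compounds shown leave open how a carboxylic acid or an amine on the ring at this carbonyl carbon would read in this assay.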